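The source may hold more compounds than are shown below. What is called first, only, known or untested is meant among the compounds shown, and "the series" means these compounds.

Measured compounds:
- Compound 1, `O=C(/C=C/c1ccc2c(c1)B(O)OC2)c1cccnc1`, gives 20500 nM in a functional assay on HCT-116 cells (Homo sapiens) for cytotoxicity, read by MTT assay, with a stated time of 48 h; a higher number here means a weaker inhibitor, a lower number a stronger inhibitor.
- Compound 2, `O=C(/C=C/c1ccc2c(c1)B(O)OC2)c1cccc(F)c1`, gives 6700 nM in this assay.
- Compound 3, `O=C(/C=C/c1ccc2c(c1)B(O)OC2)c1ccccc1O`, gives 77900 nM in this assay.

Compound 2 carries the lowest number of the three in this assay; compound 1 lies above it by a 3.1-fold lower number from compound 1 to compound 2 (0.49 log units; beyond the scatter) and compound 3 lies above it by a 12-fold higher number from compound 2 to compound 3 (1.07 log units; beyond the scatter), both steps beyond the scatter. Compound 4, `COCOc1cccc(C(=O)/C=C/c2ccc3c(c2)B(O)OC3)c1`, has not yet been measured. It differs from compound 2 by one change: methoxymethoxy in place of fluoro on an aromatic carbon.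

Going by the values given here, no measured step exchanges fluoro for methoxymethoxy, so the bearing of the three known steps is indirect. The step from compound 2 to compound 3, in which an oxygen-bearing group replaced the fluoro, raised the number by a 12-fold higher number from compound 2 to compound 3 (1.07 log units; beyond the scatter), a large step, and the step from compound 1 to compound 3 raised it by a 3.8-fold higher number from compound 1 to compound 3 (0.58 log units; beyond the scatter). Both point the same way when an oxygen group enters the ring, though neither is at the same place as the change in compound 4. A modest rise is therefore expected for compound 4, amounting to a 2.2-fold higher number from compound 2 to compound 4 (0.35 log units; beyond the scatter). Compound 4 is estimated at 15000 nM in this assay, with a likely range from 5000 nM to 45000 nM.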

Compound 4, half-maximal inhibitory concentration: 13300 nM
Compound 4: the middle estimate sits 1.1-fold (0.05 log units) above what was measured, and the stated range covers the measured number.
By their numbers in this assay, from the lowest: compounds 2, 4 and 1 (each within the scatter of the next, the first and the last beyond it); then compound 3.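

In this assay, methoxymethoxy in place of fluoro on this aromatic carbon, meta to a large group, gives a 2.0-fold higher number from compound 2 to compound 4 (0.30 log units; within the scatter), so at this place the change from a single fluorine to the larger methoxymethoxy group leaves no difference that can be told from the scatter. The earlier compounds shown here held no change at this place, and the large step of a 12-fold higher number from compound 2 to compound 3 (1.07 log units; beyond the scatter), which brought in an oxygen-bearing group elsewhere on the ring, is not repeated here, so the entry of oxygen on the ring does not by itself go with a step of that size across compounds 2, 3 and 4. Nothing shown bears on why this exchange behaves as it does.

On these data alone, what remains open is whether the tolerance seen here extends to other groups on the same aromatic carbon, such as an amine, a carboxylic acid or a longer alkoxy chain. As far as these compounds go, it is also open whether the high number of compound 3, at 77900 nM, belongs to the hydroxy group itself or to the place it occupies, which a hydroxy group on the same aromatic carbon as the methoxymethoxy group would help to separate.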